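A few compounds are considered here, and "the series" means these few. Any claim that something is new, unique, unknown or untested is made for them only; others in the source may bear on it.

Among the compounds with values here, in a functional assay on JeKo-1 cells (Homo sapiens) for inhibition, read by luminescence and CellTiter-Glo, with a stated time of 72 h (on this read-out higher numbers stand for weaker inhibition and lower numbers for stronger inhibition), compound 1 (`O=C(CCl)N1CCCC(n2nc(-c3ccc(Oc4ccccc4)cc3)cc2CO)C1`) gives 7800 nM and holds the second highest of the three numbers measured so far. Compound 2 (`C/C=C/C(=O)Nc1cccc(Cn2nc(-c3ccc(Oc4ccccc4)cc3)cc2C(=O)OCC)c1`) stands higher at 16700 nM and compound 3 (`O=C(CCl)Nc1ccc(Cn2nc(-c3ccc(Oc4ccccc4)cc3)cc2C(=O)O)cc1`) stands lower at 2500 nM and both gaps from compound 1 lie beyond the scatter. No two of these compounds differ in one place only, so no measured step bears directly on the next comparison.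

Compound 4 (`CCOC(=O)c1cc(-c2ccc(Oc3ccccc3)cc2)nn1C1CCCN(C(=O)CCl)C1`) keeps the core of compound 1 and its 1-((chloromethyl)carbonyl)piperidin-3-yl group, but has ethoxycarbonyl in place of hydroxymethyl on an aromatic carbon. Within the data shown here, the only indirect guide is compound 2, which also carries ethoxycarbonyl and gives 16700 nM but differs from compound 4 elsewhere as well. That number hints at a slight shift towards weaker inhibition, so only a small step, probably none beyond the scatter, is expected in this assay for this change. The estimated change is a 1.2-fold higher number from compound 1 to compound 4 (0.06 log units; within the scatter) and would remain within the scatter. Compound 4 is expected to give about 9000 nM with an estimated range from 3000 nM to 27000 nM in this measurement.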

Compound 4, half-maximal inhibitory concentration: 800 nM
Estimate against measurement, compound 4: 11-fold (1.05 log units) above; the measured number lies below the stated range.
By their numbers in this assay, from the lowest: compound 4; then compound 3; then compound 1; then compound 2.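

In this assay the change on this aromatic carbon, next to the ring atom that bears a 1-((chloromethyl)carbonyl)piperidin-3-yl group, is far from neutral: ethoxycarbonyl in place of hydroxymethyl gives a 9.8-fold lower number from compound 1 to compound 4 (0.99 log units; beyond the scatter) and so moves the read-out towards stronger inhibition, by a margin beyond the scatter. Within the data shown here, the earlier compounds could not show this, as no two of them differed in one place only, and this is the first step that ties a shift in the number to the group at this position alone. Nothing measured here bears on the reason for the shift.

On these data alone, the step rests on a single pair with one substituent on the ring nitrogen, so it remains open whether ethoxycarbonyl has a similar effect on compounds that carry a different group there. Also open, as far as these compounds go, is how the number would respond to other groups at this position, such as methoxycarbonyl, a primary carboxamide or a nitrile, and these would be needed to tell whether the gain depends on the whole ethoxycarbonyl group or simply on the absence of hydroxymethyl.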